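Chloro in Place of Methyl, Starting from Compound 2

The source may hold more compounds than are shown below. What is called first, only, known or untested is meant among the compounds shown, and "the series" means these compounds.

Compound 1, `Cc1cccc(C(=O)NCN2CCC(c3ccccn3)CC2)c1`, gives 67% in a functional assay on HEK293 cells for agonist activity at D(4) dopamine receptor (Homo sapiens), read by FLIPR; a lower number here means a smaller maximal response, a higher number a larger maximal response.
Compound 2, `Cc1cc(C(=O)NCN2CCC(c3cccc[n+]3[O-])CC2)ccc1F`, gives 67% in this assay.
Compound 3, `c1ccc(C2CCN(Cc3nc4ccccc4[nH]3)CC2)nc1`, gives 62% in this assay.

Compound 2 stands level with compound 1 at the digits shown, and the two share the highest number of the three; compound 3 lies a little lower, but that gap is within the scatter, so no order among the three can be read from these numbers. Compound 4, `O=C(NCN1CCC(c2cccc[n+]2[O-])CC1)c1ccc(F)c(Cl)c1`, is derived from compound 2 by chloro in place of methyl on an aromatic carbon. Going by the values given here, no pair of measured compounds isolates a change of this kind, so nothing in the data sets its size. The step of a number 2 percentage points lower from compound 2 to compound 4 (within the scatter) is expected to be small and not beyond the scatter. Compound 4 is estimated at 65%, in the range 50% to 80%.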

Compound 4, largest response reached (reported as efficacy), in percent of the reference or control that the assay uses: 67%
Compound 4: middle estimate off by 2 percentage points, on the low side, and the stated range covers the measured number.
By their numbers in this assay, from the lowest: compounds 3, 1, 2 and 4 (each within the scatter of the next).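

With chloro in place of methyl on this aromatic carbon, ortho to a fluoro group, this assay shows no change at the digits printed from compound 2 to compound 4 (within the scatter), the first step measured at this position. In this one pair, the 3-chloro-4-fluorophenyl group and the 4-fluoro-3-methylphenyl group cannot be told apart by their maximal response. Nothing measured here offers an explanation for this result.

The compounds shown leave open whether a methoxy group, a trifluoromethyl group or an amine on this carbon would also leave the maximal response unchanged. They also leave open whether the same exchange would read alike on compound 1, which has its methyl without the fluoro group.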